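Series notes: the step from compound 3 to compound 4

This account rests on a few compounds, and the source may have more. Where it says the series, first, only, none or still open, it means among the compounds named here.

Among the compounds with values here, compound 1 `Nc1nc(Cl)c(-c2ncco2)c(N[C@@H]2C[C@H](CO)[C@@H](O)[C@H]2O)n1` is one of three compounds measured so far in an ADME assay on cells (Homo sapiens) for cytotoxicity, read by polymerase chain reaction, with a stated time of 3 days; a lower number here means that less compound is tolerated, a higher number that more compound is tolerated. In this assay compound 1 reaches only the limit > 25000 nM, not a number. Compound 2 `Nc1nc(Cl)c(-c2cc3ccccc3s2)c(N[C@@H]2C[C@H](CO)[C@@H](O)[C@H]2O)n1` gives in this assay likewise only the limit > 25000 nM. The step that the two limits leave unreadable from compound 1 to compound 2 therefore cannot be read. Compound 3 `CCCNc1nc(C)c(-c2nc3ccccc3s2)c(N[C@@H]2C[C@H](CO)[C@@H](O)[C@H]2O)n1` stands at the same point, and in this assay compound 3 shows only the limit > 25000 nM. All three values sit at one place, (the limit of > 25000 nM in this assay, at which 3 of the 3 values shown sit), and none of them is a number.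

Compound 4 `Cc1nc(NCc2cccs2)nc(N[C@@H]2C[C@H](CO)[C@@H](O)[C@H]2O)c1-c1nc2ccccc2s1` differs from compound 3 by thiophen-2-yl in place of ethyl on a saturated chain carbon bound to a nitrogen on an aromatic ring. Within the data shown here, no measured step bears on this change: the single step between measured compounds is unreadable, and every compound measured sits at the limit. No shift beyond the scatter is expected, so the expected step is a step that the limit leaves unreadable from compound 3 to compound 4. Compound 4 is therefore estimated in this assay at 30000 nM, within 10000 nM to 100000 nM, and most likely again only a limit.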

Compound 4, half-maximal cytotoxic concentration: 6000 nM
Compound 4: the middle estimate sits 5.0-fold (0.70 log units) above what was measured; the whole stated range lies above it.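

Within the data shown here, replacing propylamino with ((thiophen-2-yl)methyl)amino gives an at least 4.1-fold lower number from compound 3 to compound 4 (0.61 log units; beyond the scatter) in this assay, the first readable step. This shows that a change at this amino substituent can move the read-out, whereas the step from 1,3-oxazol-2-yl to 1-benzothiophen-2-yl cannot be read. Compound 4 is the only compound shown with a measured number rather than a limit: the limit of > 25000 nM in this assay, at which 3 of the 4 values shown sit.

The compounds shown do not separate an effect of thiophen-2-yl itself from that of any other ring or a larger group, and a phenyl ring, a longer alkyl chain or a terminal amine in the same place would test this. The full size of the step also stays open, since the value of compound 3 is a limit and not a number, and these compounds give no cause for the step.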